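A few compounds are considered here, and "the series" means these few. Any claim that something is new, unique, unknown or untested is made for them only; others in the source may bear on it.

Measured so far:
compound 1 `CC1CCN(C(=O)CN(C)C(=O)c2ccc(S(C)(=O)=O)c([N+](=O)[O-])c2)CC1` — in an assay on isolated protein for inhibition of thyroid hormone receptor beta (Homo sapiens), read by fluorescence polarization (on this read-out lower numbers stand for stronger inhibition and higher numbers for weaker inhibition), compound 1 gives > 60000 nM, which is a limit of the assay.
compound 2 `CN(CC(=O)N1CCc2ccccc2C1)C(=O)c1ccc(S(C)(=O)=O)c([N+](=O)[O-])c1` — in this assay compound 2 gives > 60000 nM, likewise a limit.

Compound 2 thus stands at the limit, where both values shown sit (the limit of > 60000 nM in this assay, at which 2 of the 2 values shown sit). For the measured compounds named here, the only measured step, a step that the two limits leave unreadable from compound 1 to compound 2, is unreadable and offers no guide. Compound 3 `CS(=O)(=O)c1ccc(C(=O)NCC(=O)N2CCc3ccccc3C2)cc1[N+](=O)[O-]` differs from compound 2 by hydrogen in place of methyl on an amide-type nitrogen. Going by the values given here, no measured step covers such a change, so no direction can be read. Compound 3 is expected to remain at the limit, a step that the limit leaves unreadable from compound 2 to compound 3. Compound 3 is estimated at 80000 nM, range 20000 nM to 300000 nM.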

Compound 3, half-maximal inhibitory concentration: 46000 nM
Beside the measured number, compound 3's estimate is 1.7-fold (0.24 log units) above it, and the stated range covers the measured number.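

In this assay, hydrogen in place of methyl on the amide-type nitrogen gives an at least 1.3-fold lower number from compound 2 to compound 3 (0.11 log units; that floor lies within the scatter). For the compounds shown here, the true size of the step remains unknown, but this nitrogen is the first place where a change yields a number rather than a limit. The values shown still sit mostly at that limit: the limit of > 60000 nM in this assay, at which 2 of the 3 values shown sit.

Still open, as far as these compounds go, is whether the same change gives a readable number with 4-methylpiperidin-1-yl on the carbonyl carbon. Also open, from the compounds shown here alone, is how an ethyl group or a longer chain on this nitrogen would read.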